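Working notes on an ear inhibition series of three analogues

The compounds below may be only part of what the source reports. "The series", "measured", "known", "first", "only" and "open" are said of these compounds alone.

Measured so far:
compound 1, `CC(=O)OC[C@H]1O[C@H](OC(C)=O)[C@H](NC(=O)[C@@H](NCCC2OCC(C)(C)CO2)C(C)C)[C@@H](OC(C)=O)[C@@H]1OC(C)=O`: 70.6%
compound 2, `CC[C@H](C)[C@H](NCCC1OCC(C)(C)CO1)C(=O)N[C@H]1C(O)O[C@H](CO)[C@@H](O)[C@@H]1O`: 88.7%

In a functional assay on the whole organism (Ear, strain ICR) for inhibition, with Mus musculus as the target, with stated times of 30 min and 2 h, at a dose of 10 umol/kg by the oral route (a higher number here means more inhibition at the dose given (going by the name of the read-out), a lower number less inhibition), compound 1 gives 70.6%, while compound 2 gives 88.7%. Compound 2 stands highest of the two numbers available; its nearest neighbour is compound 1, whose value is lower by an amount beyond the usual scatter, so compound 2 shows the greater inhibition of the two at the dose used. Among the compounds with values here, the two compounds differ in more than one place, and no single step between them has been worked out, so nothing beyond the two values themselves is drawn from that pair.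

Compound 3, `CC(C)C[C@H](NCCC1OCC(C)(C)CO1)C(=O)N[C@H]1C(O)O[C@H](CO)[C@@H](O)[C@@H]1O`, has not yet been tested in this assay. It differs from compound 2 as follows: isobutyl in place of sec-butyl on a saturated chain carbon bound to an amine nitrogen and a carbonyl carbon. The two have the same atoms joined differently, and both branched groups sit on a saturated chain carbon bound to an amine nitrogen and a carbonyl carbon. With no measured step of this kind in the series, the expected step of a number 8.7 percentage points lower from compound 2 to compound 3 (within the scatter) is small and may fall within the scatter in either direction. Compound 3 is therefore estimated at 80%, with a range of 62% to 95%.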

Compound 3, a percentage reported as inhibition, in the whole organism at one dose (the size of the read-out at that dose, not a potency): 81.8%
Estimate against measurement, compound 3: 1.8 percentage points below; the range from low to high includes it.
By their numbers in this assay, from the lowest: compound 1; then compounds 3 and 2 (each within the scatter of the next).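

Working notes, position on the saturated chain carbon bound to an amine nitrogen and a carbonyl carbon: in this assay, placing isobutyl where sec-butyl stood gives a number 6.9 percentage points lower from compound 2 to compound 3 (within the scatter), the first single-place step read in this series. At this position, therefore, the two branched groups, which have the same heavy-atom count, cannot be told apart at the one dose tested, even though the change removes the defined stereocentre carried by sec-butyl. Nothing available on these compounds accounts for this result.

Both groups compared here are branched four-carbon groups, so the compounds shown leave open whether a straight butyl chain, a much smaller methyl, a benzyl group or a group carrying a carboxylic acid at this position would also stay within the scatter of compound 2. They also leave open how the free sugar compares with its acetyl-bearing form when the group at this position is held constant, since compound 1 and compound 2 differ in more than one place.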